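From 3-Aminophenyl to 4-Methylphenyl on the Aromatic Nitrogen

The source may report more compounds than this note shows. Statements on the series, on what has been measured and on what is new or still open speak of the compounds shown alone.

In a functional assay on MCF7 cells (Homo sapiens) for cytotoxicity, read by MTT assay, with a stated time of 96 h (a lower number here means a stronger inhibitor, a higher number a weaker inhibitor), compound 1 (`COc1cc(C(=O)c2cn(-c3ccccc3)cc2-c2ccccc2Cl)cc(OC)c1OC`) gives 76 nM, compound 2 (`COc1cc(C(=O)c2cn(-c3cccc(N)c3)cc2-c2ccccc2Cl)cc(OC)c1OC`) gives 40 nM and compound 3 (`COc1cc(C(=O)c2cn(-c3cccc(N)c3)cc2-c2ccc(N)cc2)cc(OC)c1OC`) gives 14 nM. Compound 2 stands level with compound 1 within the scatter, while compound 3 lies lower, beyond the scatter. Compound 4 (`COc1cc(C(=O)c2cn(-c3ccc(C)cc3)cc2-c2ccccc2Cl)cc(OC)c1OC`) has not yet been measured. It carries 4-methylphenyl in place of 3-aminophenyl on an aromatic nitrogen.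

The step that bears most directly on this change is a 1.9-fold lower number from compound 1 to compound 2 (0.28 log units; within the scatter), where amino replaces hydrogen on the group at that nitrogen, and it stays within the scatter. The other step, a 2.9-fold lower number from compound 2 to compound 3 (0.46 log units; beyond the scatter), is modest and concerns the 2-chlorophenyl group, which compound 4 keeps, so it says little here. Among the compounds with values here, no measured compound carries a methyl group. In this assay, the expected change is therefore small, within the scatter and, if anything, toward a higher number: an estimated 1.5-fold higher number from compound 2 to compound 4 (0.18 log units; within the scatter). For compound 4 the estimated value is 60 nM, with an expected range of 20 nM to 180 nM.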

Compound 4, half-maximal inhibitory concentration: 180 nM
Beside the measured number, compound 4's estimate is 3.0-fold (0.48 log units) below it; the measured number falls inside the stated range.
By their numbers in this assay, from the lowest: compound 3; then compounds 2 and 1 (each within the scatter of the next); then compound 4.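

In this assay, the group on the aromatic nitrogen now moves the number beyond the scatter, which the earlier amino step at this position did not do: replacing 3-aminophenyl with 4-methylphenyl gives a 4.5-fold higher number from compound 2 to compound 4 (0.65 log units; beyond the scatter). Methyl in place of hydrogen alone gives a 2.4-fold higher number from compound 1 to compound 4 (0.37 log units; beyond the scatter), so this position is sensitive even to a single added methyl group, and in the direction of a weaker inhibitor. No measurement shown here explains this shift.

The change from compound 2 to compound 4 alters both the group and where it sits on the phenyl, and the compounds shown do not separate the two. Also open, from the compounds shown here alone, are how a hydroxyl or a carboxylic acid on that phenyl would fare, and whether the methyl penalty persists with the 4-aminophenyl group of compound 3.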